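Swapping Fluoro for Chloro on the Core of Compound 1

This account rests on a few compounds, and the source may have more. Where it says the series, first, only, none or still open, it means among the compounds named here.

Measured so far:
Compound 1, `NC(=O)/C=C1\CCc2c(F)cccc21`, gives 40% in a functional assay on the whole organism with Rattus norvegicus as the target, at a dose of 20 mg/kg by the oral route; on this read-out lower numbers stand for less inhibition and higher numbers for more inhibition at the one dose given (going by the name of the read-out).
Compound 2, `NC(=O)/C=C1\CCc2cc(Cl)ccc21`, gives 30% in this assay.
Compound 3, `CCNC(=O)/C=C1\CCc2ccc(F)cc21`, gives 45% in this assay.

Among these three numbers compound 1 stands second highest. Its nearest neighbour is compound 3, whose number is slightly higher, and the furthest is compound 2, whose number is lower; both gaps lie within the usual scatter, so no real order among the three can be read from them. Compound 4, `NC(=O)/C=C1\CCc2c(Cl)cccc21`, differs from compound 1 in one place: chloro in place of fluoro on an aromatic carbon. Among the measured compounds shown here, no pair of measured compounds differs in exactly this way, so nothing measured here shows what such a swap does. The step of a number 2 percentage points lower from compound 1 to compound 4 (within the scatter) is expected to lie within the scatter, in no clear direction. Compound 4 is expected to give about 38%, between 22% and 55%.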

Compound 4, a percentage reported as inhibition, in the whole organism at one dose (the size of the read-out at that dose, not a potency): 35%
Estimate against measurement, compound 4: 3 percentage points above, and the stated range covers the measured number.
By their numbers in this assay, from the lowest: compounds 2, 4, 1 and 3 (each within the scatter of the next, the first and the last beyond it).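

Going from fluoro to chloro on this aromatic carbon, ortho to a fused ring, gives a number 5 percentage points lower from compound 1 to compound 4 (within the scatter) in this assay. Among the compounds shown here, this is the first direct comparison at this place on the shared core, and at the one dose given, the two halogens cannot be told apart. Nothing measured here offers an explanation for this result.

From the compounds shown here alone, whether a methoxy group, an amine or a carboxylic acid on this same carbon would shift the number beyond the scatter remains open, as does the effect of a plain hydrogen there.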